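The source may report more compounds than this note shows. Statements on the series, on what has been measured and on what is new or still open speak of the compounds shown alone.

Compound 1 `COc1ccc(C2N=C(SCc3ccccc3)NC(C)=C2C(=O)Nc2ccc(F)cc2)cc1OC`: 1.5%
Compound 2 `COc1ccc(C2N=C(SCc3ccccc3Cl)NC(C)=C2C(=O)Nc2ccc(F)cc2)cc1OC`: 2.6%
Compound 3 `CC1=C(C(=O)Nc2ccc(Br)cc2)C(c2ccc(Cl)cc2Cl)N=C(SCc2ccccc2)N1`: 1.5%

In a functional assay on the whole organism (artery, strain albino) with Rattus norvegicus as the target, with a stated time of 15 min, at a dose of 10 mg/kg by the oral route (on this read-out higher numbers stand for more inhibition at the one dose given (going by the name of the read-out) and lower numbers for less inhibition), all three measured compounds sit together at the low end. Compound 1 and compound 2 differ only by chloro in place of hydrogen on an aromatic carbon, and this change gave a number 1.1 percentage points higher from compound 1 to compound 2 (within the scatter). Compound 3 stands level with compound 1 at the digits given, and the difference between the two cores is not broken down here. Compound 4 `CC1=C(C(=O)Nc2ccc(Br)cc2)C(c2ccc(Cl)cc2Cl)N=C(SCc2ccccc2Cl)N1` is not yet measured; it differs from compound 3 by chloro in place of hydrogen on an aromatic carbon, the same change made from compound 1 to compound 2, at the same kind of place. Because the earlier step of a number 1.1 percentage points higher from compound 1 to compound 2 (within the scatter) stayed within the scatter, compound 4 is expected to show only a number 1 percentage points higher from compound 3 to compound 4 (within the scatter), a step of about the same size. Compound 4 is therefore estimated at 2.5% in this assay, most likely between 0% and 8%.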

Compound 4, a percentage reported as inhibition, in the whole organism at one dose (the size of the read-out at that dose, not a potency): 3.1%
Compound 4: middle estimate off by 0.6 percentage points, on the low side, and the stated range covers the measured number.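

In this assay, the chloro in place of hydrogen on an aromatic carbon gave a number 1.6 percentage points higher from compound 3 to compound 4 (within the scatter). Set beside the earlier step, the change looks alike on the two cores: the same change on two cores in this assay, a number 1.1 percentage points higher (within the scatter) from compound 1 to compound 2 and a number 1.6 percentage points higher (within the scatter) from compound 3 to compound 4, 0.5 percentage points apart, within the scatter of two such steps. This shows that the change, going from benzyl to 2-chlorobenzyl, left the read-out within the scatter on both cores, but it does not show that the change increases inhibition, nor that it would behave the same way on any other core.

The compounds shown leave open whether an amine or a carboxylic acid in place of the benzylsulfanyl group would give a number clear of the scatter in this assay. They also leave open how these compounds would read at any other dose.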